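Fluorine for Chlorine on the Carbonyl-Bound Phenyl Ring

The source may hold more compounds than are shown below. What is called first, only, known or untested is meant among the compounds shown, and "the series" means these compounds.

Of the compounds shown here, two have been tested in a functional assay on COLO 205 cells (Homo sapiens) for inhibition, read by sulforhodamine B assay, with a stated time of 48 h; a higher number here means that more compound is tolerated, a lower number that less compound is tolerated. Compound 1 `COc1ccc(-c2cc(/C=C/C(=O)c3ccc(OC)c(OC)c3)[nH]n2)cc1` gives 6160 nM in this assay. Compound 2 `COc1cc(-c2cc(/C=C/C(=O)c3ccc(Cl)c(Cl)c3)[nH]n2)cc(OC)c1OC` is recorded only as a limit of the assay, > 100000 nM, so no number is known for it. Compound 2 therefore stands at the limit of > 100000 nM in this assay, at which 1 of the 2 values shown sits, and nothing beyond that can be said of how far it lies from the measured value.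

Compound 3 `COc1cc(-c2cc(/C=C/C(=O)c3ccc(F)c(F)c3)[nH]n2)cc(OC)c1OC` has not yet been measured in this assay. It differs from compound 2 in a single place: 3,4-difluorophenyl in place of 3,4-dichlorophenyl on a carbonyl carbon. Among the compounds with values here, because compound 2 is known only through (the limit of > 100000 nM in this assay, at which 1 of the 2 values shown sits), no measured step exists to set the size of this change against. The exchange of one halogen pair for another on the same ring is expected to move the reading little, so compound 3 is expected to stay near the limit as well, with the step from compound 2 to compound 3 estimated at an at least 1.2-fold lower number from compound 2 to compound 3 (0.09 log units; that floor lies within the scatter), not clearly beyond the scatter. Compound 3 is thus estimated at 80000 nM, with a range from 20000 nM to 200000 nM.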

Compound 3, concentration lethal to 50% of the cells: 6000 nM
The estimate for compound 3 lay 13-fold (1.12 log units) above the measured number; the measured number lies below the stated range.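

On the carbonyl carbon, 3,4-difluorophenyl in place of 3,4-dichlorophenyl proves to be no neutral exchange of one halogen pair for another: in this assay it gives an at least 16-fold lower number from compound 2 to compound 3 (1.22 log units; beyond the scatter), the first step measured at this place in the series. The rest of the two structures is the same, so the whole step belongs to this one place, and the reading there clearly responds to which halogen pair the ring carries. Compound 2 is recorded only as a limit of the assay, so the step is a floor and its full size remains unknown: the limit of > 100000 nM in this assay, at which 1 of the 3 values shown sits.

The compounds shown offer only this single exchange at this place, and they do not tell whether the reading follows the kind of halogen in a regular way, or how an unsubstituted phenyl or a dibromophenyl group on the same carbonyl carbon would read in this assay. Whether a step of this size would recur on a different core also stays open, as does the reason for the step, on which the data shown give no measurement.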